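From phenoxymethyl to phenyl: what to expect for compound 3

The source may report more compounds than this note shows. Statements on the series, on what has been measured and on what is new or still open speak of the compounds shown alone.

Compound 1 `O=C(COc1ccccc1)Nc1nnc(-c2cccc(O)c2O)s1`: 16600 nM
Compound 2 `O=C(COc1ccccc1)Nc1nnc(-c2ccc(O)c(O)c2)s1`: 36100 nM

For the measured compounds named here, in a functional assay, with a stated time of 30 min, in the absence of a further agent (a higher number here means a weaker inhibitor, a lower number a stronger inhibitor), compound 2 gives 36100 nM, the higher of the two numbers so far, which makes it the weaker inhibitor of the pair. The next molecule, compound 3 `O=C(Nc1nnc(-c2ccc(O)c(O)c2)s1)c1ccccc1`, keeps the 3,4-dihydroxyphenyl group and has phenyl in place of phenoxymethyl on a carbonyl carbon.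

Going by the values given here, only one measured step is available, a 2.2-fold higher number from compound 1 to compound 2 (0.34 log units; beyond the scatter). It was modest and involved 3,4-dihydroxyphenyl in place of 2,3-dihydroxyphenyl on an aromatic carbon. It leaves the carbonyl carbon untouched, so it gives only a rough idea of how far one structural change can move the number here. Among the compounds with values here, no measured pair tests the new change, and the data favour neither direction. The expectation in this assay therefore stays close to compound 2 at 36100 nM, with no step beyond the scatter, though with wide uncertainty.

The expected change is a 1.2-fold lower number from compound 2 to compound 3 (0.08 log units; within the scatter). Compound 3 is estimated at 30000 nM, with an expected range of 10000 nM to 90000 nM.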

Compound 3, half-maximal inhibitory concentration: 23400 nM
Compound 3: the middle estimate sits 1.3-fold (0.11 log units) above what was measured; low and high end bracket the measured number.
By their numbers in this assay, from the lowest: compounds 1, 3 and 2 (each within the scatter of the next, the first and the last beyond it).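

For the compounds shown here, this is the first look at the group on the carbonyl carbon, and in this assay replacing phenoxymethyl with phenyl gives a 1.5-fold lower number from compound 2 to compound 3 (0.19 log units; within the scatter) as the measured step. Phenoxymethyl counts 8 heavy atoms and 1 hydrogen-bond acceptor, while phenyl counts 6 heavy atoms and no hydrogen-bond acceptor, yet compound 2 and compound 3 cannot be told apart here, so with the 3,4-dihydroxyphenyl group in place, this change leaves the read-out within normal measurement noise. Nothing available explains this outcome, so the result describes what was seen without saying what lies behind it.

On these data alone, this rests on a single pair of compounds, so whether the same swap would behave alike alongside the 2,3-dihydroxyphenyl group remains open. As far as these compounds go, it also remains open what an amine, a carboxylic acid or a longer carbon chain on this carbonyl carbon would do, since both groups compared here carry a six-membered aromatic ring of carbon only.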